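The source may report more compounds than this note shows. Statements on the series, on what has been measured and on what is new or still open speak of the compounds shown alone.

Measured compounds:
compound 1, `CCCSc1cc(C)c(C(=O)N=C(N)N)cc1S(C)(=O)=O`, gives 6.8 nM in a functional assay for inhibition of sodium/hydrogen exchanger (Oryctolagus cuniculus); on this read-out higher numbers stand for weaker inhibition and lower numbers for stronger inhibition
compound 2, `Cc1c(C(=O)N=C(N)N)cc(S(C)(=O)=O)c(Oc2cccnc2)c1C`, gives 23 nM in this assay

Among the measured compounds shown here, compound 1 stands lowest of the two numbers so far. Its nearest neighbour is compound 2, whose number is higher by a margin beyond the usual scatter, so compound 1 is the stronger inhibitor of this pair. For the measured compounds named here, no pair of these two compounds differs in only one place, so no single step between measured compounds can be read off.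

The next compound is compound 3, `Cc1cc(N2CCCC(O)C2)c(S(C)(=O)=O)cc1C(=O)N=C(N)N`. It is reached from compound 1 by one change: 3-hydroxypiperidin-1-yl in place of propylsulfanyl on an aromatic carbon. With no measured step of this kind in the set, the size of the change has to be guessed from the structures alone, and the replacement is a sizeable one, exchanging a short open chain for a ring bearing a hydroxyl. Compound 3 is therefore expected to sit somewhat above compound 1, with the step of a 2.9-fold higher number from compound 1 to compound 3 (0.47 log units; beyond the scatter) expected to fall beyond the scatter in the direction of weaker inhibition. The expected value for compound 3 is 20 nM, with a likely range from 5 nM to 80 nM.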

Compound 3, half-maximal inhibitory concentration: 30 nM
Beside the measured number, compound 3's estimate is 1.5-fold (0.18 log units) below it, within the range that was stated.
By their numbers in this assay, from the lowest: compound 1; then compounds 2 and 3 (each within the scatter of the next).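

In this assay the aromatic carbon ortho to a methylsulfonyl group proves sensitive to what it carries, which the first two compounds could not show: 3-hydroxypiperidin-1-yl in place of propylsulfanyl gives a 4.4-fold higher number from compound 1 to compound 3 (0.64 log units; beyond the scatter) and so moves toward weaker inhibition. The change is tolerated to a degree, however, since a six-membered non-aromatic ring bearing a hydroxyl replaces the short open chain and compound 3 still gives 30 nM in this assay. No measurement of any property of these groups bears on this step, so the result stands as an observed difference only.

The compounds shown leave open whether the ring or the hydroxyl carries the step, since plain piperidin-1-yl or a morpholine ring at this carbon would separate the two. Also open, going by these compounds, is how a longer chain such as butylsulfanyl or a simple amine such as dimethylamino would compare with propylsulfanyl at the same position.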